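Series notes: compound 1 to compound 3

The source may report more compounds than this note shows. Statements on the series, on what has been measured and on what is new or still open speak of the compounds shown alone.

Compound 1 `O=C(C1=C(OC2CCCCC2)C(=O)N(CCCn2ccnc2)C1c1ccc(Br)cc1)c1ccccc1` gives 22400 nM in a functional assay on U2OS cells (Homo sapiens) for antiproliferative activity, read by MTT assay, with a stated time of 72 h; a lower number here means a stronger inhibitor, a higher number a weaker inhibitor. Among the measured compounds shown here, the only other number comes from compound 2 `Cc1ccc(NC2=C(C(=O)c3ccccc3)C(c3ccc(Br)cc3)N(CCCn3ccnc3)C2=O)cc1`, which gives 24100 nM in this assay, and a 1.1-fold higher number from compound 1 to compound 2 (0.03 log units; within the scatter). Compound 3 `O=C(C1=C(Nc2ccc(OC(F)(F)F)cc2)C(=O)N(CCCn2ccnc2)C1c1ccc(Br)cc1)c1ccccc1` carries (4-(trifluoromethoxy)phenyl)amino in place of cyclohexyloxy on a double-bonded ring carbon. For the measured compounds named here, the one measured step that bears on this change is the (4-methylphenyl)amino in place of cyclohexyloxy on a double-bonded ring carbon, which stayed within the scatter. No step beyond the scatter is therefore expected in this assay, with a 1.0-fold lower number from compound 1 to compound 3 (0.01 log units; within the scatter). Compound 3 is estimated at 22000 nM, expected within 11000 nM to 45000 nM.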

Compound 3, half-maximal inhibitory concentration: 11500 nM
Compound 3: the middle estimate sits 1.9-fold (0.28 log units) above what was measured; low and high end bracket the measured number.
By their numbers in this assay, from the lowest: compounds 3, 1 and 2 (each within the scatter of the next, the first and the last beyond it).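

Replacing cyclohexyloxy with (4-(trifluoromethoxy)phenyl)amino on the double-bonded ring carbon gives a 1.9-fold lower number from compound 1 to compound 3 (0.29 log units; within the scatter) in this assay, so this position again shows no separation between the two groups. Trifluoromethoxy in place of methyl on an aromatic carbon gives a 2.1-fold lower number from compound 2 to compound 3 (0.32 log units; beyond the scatter), the only step shown beyond the scatter, and a modest one. No measurement at hand accounts for this step.

The compounds shown leave open how a carboxylic acid or a dimethylamino group on that aromatic carbon would read. From the compounds shown here alone, whether an unsubstituted amine on the double-bonded ring carbon would keep these numbers is also open.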